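Cytotoxicity notes on a thiadiazole amide series

The source may report more compounds than this note shows. Statements on the series, on what has been measured and on what is new or still open speak of the compounds shown alone.

Measured so far:
- compound 1 `CC(Sc1nnc(-c2ccncc2)s1)C(=O)NCc1ccccc1`: > 50000 nM
- compound 2 `O=C(CSc1nnc(-c2ccncc2)s1)NCc1ccccc1Cl`: "not determined" (no result reported)

In an ADME assay on BHK-21 cells (Mesocricetus auratus) for cytotoxicity, with a stated time of 3 days (a lower number here means that less compound is tolerated, a higher number that more compound is tolerated), compound 1 gives > 50000 nM, which is a limit of the assay rather than a number. Among the compounds with values here, compound 2 has no value in this assay, so no step between measured compounds can be read; the only fixed point is the limit of > 50000 nM in this assay, at which 1 of the 2 values shown sits.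

Compound 3 `CC(Sc1nnc(-c2ccncc2)s1)C(=O)Nc1ccc(Cl)cc1` differs from compound 1 by 4-chlorophenyl in place of benzyl on an amide-type nitrogen. Within the data shown here, with no measured step to lean on, the expectation rests on compound 1 alone, whose limit leaves the true value open above the cut-off. The step from compound 1 to compound 3 is expected to be a number no higher from compound 1 to compound 3 (the limit leaves the size open), that is, no change beyond the scatter, with the outcome most likely again a limit. Compound 3 is therefore estimated at 50000 nM in this assay, with a range from 20000 nM to 100000 nM.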

Compound 3, half-maximal cytotoxic concentration: > 50000 nM
Compound 3 ended at the assay's limit (the forecaster's own chance of this, stated with the estimate: 65%); the middle value sits exactly at the limit.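

For compound 1 and compound 3 no step can be read, since each result in this assay is a limit and not a number: the limit of > 50000 nM in this assay, at which 2 of the 3 values shown sit.

The compounds shown leave open whether any change on the amide-type nitrogen gives a single number in this assay at all.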